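The source may report more compounds than this note shows. Statements on the series, on what has been measured and on what is new or still open speak of the compounds shown alone.

Measured compounds:
- compound 1, `O=C1C(=Cc2ccc(F)cc2)C(=O)N(c2ccc(Cl)cc2)N1c1ccc(Cl)cc1`: 35600 nM
- compound 2, `COc1ccc(C=C2C(=O)N(c3ccc(Cl)cc3)N(c3ccc(Cl)cc3)C2=O)cc1OC`: > 128000 nM

Within the data shown here, in a functional assay on ECa-109 cells (Homo sapiens) for cytotoxicity, read by MTT assay, with a stated time of 72 h (a higher number here means a weaker inhibitor, a lower number a stronger inhibitor), compound 1 gives 35600 nM, the only outright number recorded. For compound 2 this assay reports only a limit, > 128000 nM. The step of an at least 3.5-fold higher number from compound 1 to compound 2 (0.55 log units; beyond the scatter) rests on the limit (the limit of > 128000 nM in this assay, at which 1 of the 2 values shown sits). The unmeasured compound 3, `O=C1C(=Cc2ccc(Cl)cc2Cl)C(=O)N(c2ccc(Cl)cc2)N1c1ccc(Cl)cc1`, differs from compound 1 in one place: 2,4-dichlorophenyl in place of 4-fluorophenyl on a double-bonded chain carbon bound to a double-bonded ring carbon. Among the measured compounds shown here, the one measured step that bears on this position, an at least 3.5-fold higher number from compound 1 to compound 2 (0.55 log units; beyond the scatter), involved a different aryl group, so it sets no direction for a 2,4-dichlorophenyl. Compound 3 is therefore expected to sit near compound 1, with a step of a 1.3-fold higher number from compound 1 to compound 3 (0.10 log units; within the scatter) that is not expected to reach beyond the scatter. For compound 3 the estimate in this assay is 45000 nM, with a range from 15000 nM to 120000 nM.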

Compound 3, half-maximal inhibitory concentration: 60200 nM
Beside the measured number, compound 3's estimate is 1.3-fold (0.13 log units) below it; low and high end bracket the measured number.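

In this assay the step of a 1.7-fold higher number from compound 1 to compound 3 (0.23 log units; within the scatter) shows that 2,4-dichlorophenyl and 4-fluorophenyl cannot be told apart on a double-bonded chain carbon bound to a double-bonded ring carbon, so this position accepts at least one change of aryl group with no shift beyond the scatter. The step of an at least 2.1-fold lower number from compound 2 to compound 3 (0.32 log units; beyond the scatter) sets compound 3 apart from compound 2 as well, and among the three compounds the weakening therefore goes with 3,4-dimethoxyphenyl alone rather than with every replacement of 4-fluorophenyl. Compound 2 carries a limit and not a number, and this step rests on it: the limit of > 128000 nM in this assay, at which 1 of the 3 values shown sits.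

Going by these compounds, it remains open whether a single methoxy group would be enough to weaken the compounds or whether both are needed. On these data alone, how an aryl group bearing an amine or a carboxylic acid would behave at this position also remains unknown.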